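A few compounds are considered here, and "the series" means these few. Any claim that something is new, unique, unknown or untested is made for them only; others in the source may bear on it.

Compound 1, `Nc1nc(NCc2ccccc2)c2ncn(/C=C3/CC3(CO)CO)c2n1`: > 24000 nM
Compound 2, `Nc1nc(NC2CCCC2)c2ncn(/C=C3/CC3(CO)CO)c2n1`: > 20000 nM

Both numbers come from an ADME assay on Akata cells (Homo sapiens) for cytotoxicity, with a stated time of 7 days; a higher number here means that more compound is tolerated, a lower number that less compound is tolerated. For compound 1 the value of > 24000 nM is a limit of the assay rather than a measured number. For compound 2 the value of > 20000 nM is likewise a limit, so compound 2 stands at the limit of > 20000 nM in this assay, at which 1 of the 2 values shown sits. Among the measured compounds shown here, the one measured step, a step that the two limits leave unreadable from compound 1 to compound 2, is therefore unreadable, and the two limits sit within the scatter of each other, so no order can be drawn between compound 1 and compound 2.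

Compound 3, `CCCCCCOc1nc(N)nc2c1ncn2/C=C1/CC1(CO)CO`, has not been measured in this assay. It differs from compound 2 by hexyloxy in place of cyclopentylamino on an aromatic carbon. No measured step bears on this change; the only step shown is unreadable. With nothing pointing either way, no step beyond the scatter is expected in this assay, and another limit is the most likely outcome. Compound 3 is therefore estimated at 25000 nM, between 10000 nM and 60000 nM. The step that the limit leaves unreadable from compound 2 to compound 3 that this estimate implies is expected to stay within the scatter.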

Compound 3, half-maximal cytotoxic concentration: > 20000 nM
Compound 3 ended at the assay's limit; the forecaster's own chance of this, stated with the estimate: 85%; the middle value lies beyond the limit too.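

In this assay, compound 1, compound 2 and compound 3 all give limits of the assay rather than measured numbers, so no step among them can be read: the limit of > 20000 nM in this assay, at which 2 of the 3 values shown sit.

The compounds shown leave open where the true half-maximal cytotoxic concentration of each lies, and whether benzylamino, cyclopentylamino or hexyloxy on the shared core changes it at all.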